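Replacing a Hydroxymethyl with a Hydroxycyclobutyl on the Morpholine Ring

The source may report more compounds than this note shows. Statements on the series, on what has been measured and on what is new or still open speak of the compounds shown alone.

The study concerns compounds sharing one core, read in an assay on isolated protein for inhibition of thyroid hormone receptor beta (Homo sapiens), read by fluorescence, with a stated time of 30 min; a higher number here means a weaker inhibitor, a lower number a stronger inhibitor. For the measured compounds named here, compound 1 `COc1cc(C(=O)N2CC(C)OCC2CO)cc2nc(N[C@H](C)c3cccc(Cl)c3)oc12` gives 10 nM, the highest of the two numbers measured so far. Compound 2 `COc1cc(C(=O)N2C[C@H](C)OC[C@@H]2CCO)cc2nc(N[C@H](C)c3cccc(Cl)c3)oc12` gives 4 nM in this assay. Going by the values given here, the one measured step is a 2.5-fold lower number from compound 1 to compound 2 (0.40 log units; beyond the scatter), a modest gain when the hydroxyl-bearing chain is extended.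

Compound 3 `COc1cc(C(=O)N2CC(C)OCC2C2CC(O)C2)cc2nc(N[C@H](C)c3cccc(Cl)c3)oc12`, not yet measured, differs from compound 1 by 3-hydroxycyclobutyl in place of hydroxymethyl on a saturated ring carbon. Among the compounds with values here, the only step that bears on this is the one from compound 1 to compound 2, where a slightly longer hydroxyl-bearing group gave a lower number beyond the scatter. Whether a ring-shaped hydroxyl-bearing group behaves in the same way cannot be read from that single step, so the expectation is cautious: a small decrease in the number, or none beyond the scatter, is expected for compound 3 in this assay. The expected step is a 1.4-fold lower number from compound 1 to compound 3 (0.15 log units; within the scatter). Compound 3 is therefore estimated at 7 nM, with a range from 2.5 nM to 20 nM.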

Compound 3, half-maximal inhibitory concentration: 2 nM
For compound 3 the middle estimate is 3.5-fold (0.54 log units) above the measured one; measured number outside the range, below it.
By their numbers in this assay, from the lowest: compounds 3 and 2 (each within the scatter of the next); then compound 1.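

On this saturated ring carbon, next to the ring nitrogen, this assay shows a 5.0-fold lower number from compound 1 to compound 3 (0.70 log units; beyond the scatter) when 3-hydroxycyclobutyl replaces hydroxymethyl. The position therefore accepts much more than a slightly longer hydroxyl-bearing chain: the group grows from 2 heavy atoms to 5 and gains a four-membered carbon ring, yet the number falls rather than rises, while the count of one hydrogen-bond donor and one hydrogen-bond acceptor stays the same. No measurement here explains this gain, so the reason for it remains unknown.

The compounds shown do not reveal whether the hydroxyl itself matters, which a plain cyclobutyl group or a 3-aminocyclobutyl group at this position would help to test, and they do not show whether a still longer hydroxyalkyl chain or a larger ring such as hydroxycyclopentyl would continue the trend. The structure of compound 3 also fixes no spatial arrangement on the 3-hydroxycyclobutyl or on the ring carbon that carries it, so it remains open which arrangement accounts for its value.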